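The source may hold more compounds than are shown below. What is called first, only, known or untested is meant among the compounds shown, and "the series" means these compounds.

Working notes on the shared core carrying a morpholine sulfonyl group, with variation at the double-bonded nitrogen. In an ADME assay on WI-38 cells (Homo sapiens) for cytotoxicity, read by sulforhodamine B assay, with a stated time of 24 h (on this read-out lower numbers stand for stronger inhibition and higher numbers for weaker inhibition), compound 1 `O=C1Nc2ccc(S(=O)(=O)N3CCOCC3)cc2/C1=N/NC(=O)c1ccccc1` gives 295000 nM, compound 2 `O=C1Nc2ccc(S(=O)(=O)N3CCOCC3)cc2/C1=N/c1cccc(C(F)(F)F)c1` gives 226000 nM, and compound 3 `O=C1Nc2ccc(S(=O)(=O)N3CCOCC3)cc2/C1=N/c1ccc(Cl)cc1` gives 468000 nM. Compound 3 holds the highest of the three numbers; its gap to compound 1 is within the scatter, while the step of a 2.1-fold higher number from compound 2 to compound 3 (0.32 log units; beyond the scatter) is modest but beyond it. The two other steps, a 1.3-fold lower number from compound 1 to compound 2 (0.12 log units; within the scatter) and a 1.6-fold higher number from compound 1 to compound 3 (0.20 log units; within the scatter), both fall inside the scatter.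

Compound 4 `Cc1ccc(/N=C2\C(=O)Nc3ccc(S(=O)(=O)N4CCOCC4)cc32)cc1` is the next member to go into this assay. Relative to compound 3 the change is methyl in place of chloro on an aromatic carbon. Among the measured compounds shown here, none of the measured steps is a swap of one small group for another on the same aromatic carbon; the closest case is the step from a 3-(trifluoromethyl)phenyl to a 4-chlorophenyl on the double-bonded nitrogen, which moved the number only modestly. The step of a 1.2-fold lower number from compound 3 to compound 4 (0.07 log units; within the scatter) is therefore expected to be small, with no clear direction and most likely within the scatter. For compound 4 the number in this assay is estimated at 400000 nM, with a range from 200000 nM to 800000 nM.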

Compound 4, half-maximal inhibitory concentration: 309000 nM
Compound 4: the middle estimate sits 1.3-fold (0.11 log units) above what was measured, within the range that was stated.
By their numbers in this assay, from the lowest: compounds 2, 1, 4 and 3 (each within the scatter of the next, the first and the last beyond it).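

In this assay, among the compounds shown here, methyl in place of chloro on an aromatic carbon, para to a large group, gives a 1.5-fold lower number from compound 3 to compound 4 (0.18 log units; within the scatter), the first direct reading of a swap at this place on the ring, and a swap of 4-chlorophenyl to 4-methylphenyl leaves the two compounds inseparable. The wider exchanges on the double-bonded nitrogen, a 1.4-fold higher number from compound 2 to compound 4 (0.14 log units; within the scatter) and a 1.0-fold higher number from compound 1 to compound 4 (0.02 log units; within the scatter), also stay inside the scatter, so compound 4 cannot be told apart from any of the other three, while the pair of compound 2 and compound 3 remains the one exception, with a 2.1-fold higher number from compound 2 to compound 3 (0.32 log units; beyond the scatter). No separate measurement bears on this result or accounts for these steps.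

As far as these compounds go, whether the same aromatic carbon tolerates an amine or a carboxylic acid as it does chloro and methyl remains open, as does the outcome for a longer chain such as propyl in place of methyl. All four compounds also share the morpholine sulfonyl group, so the effect on this read-out of replacing that morpholine with a piperidine or an open-chain amine cannot be judged from them.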